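Replacing the aryl group on a shared core

The compounds below may be only part of what the source reports. "The series", "measured", "known", "first", "only" and "open" are said of these compounds alone.

In a functional assay on MDA-MB-468 cells (Homo sapiens) for cytotoxicity, read by resazurin assay, with a stated time of 72 h (on this read-out lower numbers stand for stronger inhibition and higher numbers for weaker inhibition), compound 2 `O=[N+]([O-])c1ccc(-c2nnc(CCSC(=S)NCc3cccnc3)o2)cc1` gives 4600 nM, and compound 1 `FC(F)(F)c1ccc(-c2nnc(CCSC(=S)NCc3cccnc3)o2)cc1` gives 5490 nM. Within the data shown here, the only measured step, a 1.2-fold lower number from compound 1 to compound 2 (0.08 log units; within the scatter), is within the scatter, so compound 2 stands alongside compound 1 rather than apart from it. Compound 3 `S=C(NCc1cccnc1)SCCc1nnc(-c2cnccn2)o1` differs from compound 2 by pyrazin-2-yl in place of 4-nitrophenyl on an aromatic carbon. No measured step bears directly on this change, as the single step shown concerns nitro in place of trifluoromethyl and was small. The step of a 1.3-fold higher number from compound 2 to compound 3 (0.12 log units; within the scatter) is therefore expected to stay near the scatter, with no clear direction. Compound 3 is estimated at 6000 nM, ranging from 2000 nM to 20000 nM.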

Compound 3, half-maximal inhibitory concentration: 1710 nM
For compound 3 the middle estimate is 3.5-fold (0.55 log units) above the measured one; the whole stated range lies above it.
By their numbers in this assay, from the lowest: compound 3; then compounds 2 and 1 (each within the scatter of the next).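

In this assay, among these compounds, this position on the shared core responds to the kind of ring it carries: a 2.7-fold lower number from compound 2 to compound 3 (0.43 log units; beyond the scatter) is the first step here beyond the scatter, while the exchange of nitro for trifluoromethyl was not. Pyrazin-2-yl, a six-membered aromatic ring with 2 hetero atoms, therefore does more here than that exchange did. Nothing given here accounts for this change. The compounds shown leave open whether a plain phenyl or a pyridin-2-yl group would match pyrazin-2-yl, and whether a saturated ring such as morpholine would hold the gain.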